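Adding a methoxy group: estimating cytotoxicity for compound 4

The source may report more compounds than this note shows. Statements on the series, on what has been measured and on what is new or still open speak of the compounds shown alone.

Compound 1 `CC(C)=CCOc1cccc(Nc2nccs2)c1` and compound 2 `COc1ccc(Nc2nccs2)cc1OCC=C(C)C` share one core, and compound 2 carries one extra group, (methoxy in place of hydrogen on an aromatic carbon). In a functional assay on MT2 cells (Homo sapiens) for cytotoxicity, read by MTT assay (on this read-out lower numbers stand for higher toxicity in this test and higher numbers for lower toxicity in this test), compound 1 gives 23000 nM, and compound 2 gives 42000 nM, a step of a 1.8-fold higher number from compound 1 to compound 2 (0.26 log units; within the scatter). Compound 3 `COc1ccnc(Nc2ccc(Cl)c(OCC=C(C)C)c2)n1` is built on a different core; the difference between the two cores is not broken down here. In this assay compound 3 gives 9000 nM, the lowest of the three numbers. Compound 4 `COc1cc(OC)nc(Nc2ccc(Cl)c(OCC=C(C)C)c2)n1` differs from compound 3 by methoxy in place of hydrogen on an aromatic carbon. This is the same kind of change as from compound 1 to compound 2, but the surroundings differ: in compound 2 the new group sits on a six-membered aromatic ring of carbon only, ortho to a (3-methylbut-2-en-1-yl)oxy group and para to a (1,3-thiazol-2-yl)amino group, whereas in compound 4 it sits on a six-membered aromatic ring with 2 nitrogen, next to the ring nitrogen, meta to a large group, meta to a methoxy group and opposite the ring nitrogen. The expectation rests on the step of a 1.8-fold higher number from compound 1 to compound 2 (0.26 log units; within the scatter), which stayed within the scatter. For compound 4 a similarly small step is expected, a 1.3-fold higher number from compound 3 to compound 4 (0.12 log units; within the scatter). Compound 4 is therefore estimated at 12000 nM, within a range from 5000 nM to 30000 nM.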

Compound 4, half-maximal cytotoxic concentration: 28000 nM
Compound 4: the middle estimate sits 2.3-fold (0.37 log units) below what was measured, within the range that was stated.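

The same swap of hydrogen for methoxy, this time on a six-membered aromatic ring with 2 nitrogen, gives a 3.1-fold higher number from compound 3 to compound 4 (0.49 log units; beyond the scatter) in this assay. Set beside the earlier step, this result does not differ from it by more than repeated measurements would: the same change on two cores in this assay, a 1.8-fold higher number (0.26 log units; within the scatter) from compound 1 to compound 2 and a 3.1-fold higher number (0.49 log units; beyond the scatter) from compound 3 to compound 4, 1.7-fold (0.23 log units) apart, within the scatter of two such steps. Among the compounds shown here, the size of the step therefore appears to carry from one core to the other, but this rests on only two pairs, and only the second pair stands clear of the scatter by itself, so the result gives neither a rule for other cores nor a reason for the shift.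

For the compounds shown here, the only group entering in these pairs is methoxy, so it remains open whether an ethoxy group, a longer chain or an amine at the same place would shift the number in a similar way. Going by these compounds, it also remains open whether the methoxy step would hold on a core with a different group in place of the (3-methylbut-2-en-1-yl)oxy chain.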